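Dithiocarbamate phosphate esters: chain length and ring size

The compounds below may be only part of what the source reports. "The series", "measured", "known", "first", "only" and "open" are said of these compounds alone.

Measured so far:
compound 1 `CCCCCCCCOP(=O)(O)OCCSC(=S)N1CCCCCC1` — 56800 nM
compound 2 `CCCCCCOP(=O)(O)OCCSC(=S)N1CCCC1` — > 100000 nM

In a functional assay on PC-3 cells (Homo sapiens) for inhibition, read by MTT assay, with stated times of 18 h and 4 h (on this read-out lower numbers stand for stronger inhibition and higher numbers for weaker inhibition), compound 1 gives 56800 nM. Compound 2 returns only a limit of this assay, > 100000 nM, and not a number; (the limit of > 100000 nM in this assay, at which 1 of the 2 values shown sits). Compound 3 `CCCCCCCCOP(=O)(O)OCCSC(=S)N1CCCC1` is not yet measured in this assay. It differs from compound 2 by ethyl in place of hydrogen on a saturated chain carbon, six bonds along the chain from an oxygen on an unsaturated carbon. Within the data shown here, no measured pair isolates this change, so its effect is open; a small step toward stronger inhibition, or none beyond the scatter, is expected. The step of an at least 1.2-fold lower number from compound 2 to compound 3 (0.09 log units; that floor lies within the scatter) is estimated. Compound 3 is expected near 80000 nM, within 30000 nM to 200000 nM.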

Compound 3, half-maximal inhibitory concentration: > 100000 nM
Compound 3 was reported as a limit (the forecaster's own chance of this, stated with the estimate: 45%); middle value at least 1.2-fold (0.09 log units) from the limit.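

In this assay, compound 3 is a limit, so ethyl in place of hydrogen on the chain does not move the pyrrolidin-1-yl series to a readable number. The size of that step cannot be read, because both compounds of the pair are limits: the limit of > 100000 nM in this assay, at which 2 of the 3 values shown sit.

The ring change can now be read on its own: pyrrolidin-1-yl in place of azepan-1-yl on a thiocarbonyl carbon gives an at least 1.7-fold higher number from compound 1 to compound 3 (0.24 log units; that floor lies within the scatter).

Open, on these data alone, is whether piperidin-1-yl on the thiocarbonyl carbon gives a number rather than a limit. Also open, as far as these compounds go, is whether a longer chain, such as decyl, does so with pyrrolidin-1-yl or shifts the azepan-1-yl result.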